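Dropping the Methoxy Group From the Aniline Ring

This account rests on a few compounds, and the source may have more. Where it says the series, first, only, none or still open, it means among the compounds named here.

Of the compounds shown here, three built on one shared core have been tested in a functional assay on A549 cells (Homo sapiens) for antiproliferative activity, read by MTT assay, with a stated time of 72 h; a lower number here means a stronger inhibitor, a higher number a weaker inhibitor. Compound 1 `COc1cc2ncnc(Nc3ccc(Br)cc3)c2cc1OCCCCC(=O)Nc1ccc(S(N)(=O)=O)cc1` gives only a limit there, > 40000 nM. Compound 2 `COc1ccc(Nc2ncnc3cc(OC)c(OCCCCC(=O)Nc4ccc(S(N)(=O)=O)cc4)cc23)cc1` likewise gives only a limit, > 40000 nM. Within the data shown here, compound 3 `COc1ccccc1Nc1ncnc2cc(OC)c(OCCCCC(=O)Nc3ccc(S(N)(=O)=O)cc3)cc12` is the one member of the set that gives a true number, 24100 nM. The other two values are limits (the limit of > 40000 nM in this assay, at which 2 of the 3 values shown sit). The steps leading to compound 3 are an at least 1.6-fold lower number from compound 1 to compound 3 (0.22 log units; that floor lies within the scatter) and an at least 1.6-fold lower number from compound 2 to compound 3 (0.22 log units; that floor lies within the scatter), while a step that the two limits leave unreadable from compound 1 to compound 2 cannot be read at all.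

Compound 4 `COc1cc2ncnc(Nc3ccccc3)c2cc1OCCCCC(=O)Nc1ccc(S(N)(=O)=O)cc1` differs from compound 3 in a single place: hydrogen in place of methoxy on an aromatic carbon. Among the measured compounds shown here, the only measured steps that touch the aniline ring are both small, with floors inside the scatter, and both begin from compounds that reach only a limit. The change here therefore gives no ground for expecting a stronger inhibitor; the likelier outcome is a value near the limit, possibly reported again as a limit alone. The resulting step is expected to be a 1.9-fold higher number from compound 3 to compound 4 (0.27 log units; within the scatter). For compound 4 in this assay the estimated value is 45000 nM, ranging from 15000 nM to 150000 nM.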

Compound 4, half-maximal inhibitory concentration: > 40000 nM
Compound 4 was reported as a limit; the forecaster's own chance of this, stated with the estimate: 60%; the middle value lies beyond the limit too.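

Putting hydrogen in place of methoxy on the aromatic carbon of the 2-methoxyphenyl group gives, in this assay, an at least 1.6-fold higher number from compound 3 to compound 4 (0.22 log units; that floor lies within the scatter), so plain phenyl now serves as the reference for this position, but the printed floor does not show that the methoxy group matters there. The steps linking compound 4 to compound 1 and to compound 2 cannot be read, as both ends of each are limits. Compound 3 remains the only compound here with a true number, and the others all stop at the same limit: the limit of > 40000 nM in this assay, at which 3 of the 4 values shown sit.

From the compounds shown here alone, the true size of the step stays open, as the value of compound 4 is a limit and not a number. Also open, going by these compounds, is whether an amine or a hydroxyl group on this same carbon would give a true number.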